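The compounds below may be only part of what the source reports. "The series", "measured", "known", "first", "only" and "open" are said of these compounds alone.

Compound 3 `COc1cc(O)ccc1/C=C/C(=O)c1ccc(N)cc1` is the weakest of the three measured compounds in an assay on isolated protein for inhibition of DNA topoisomerase 1 (Homo sapiens), tested at 100 uM (on this read-out higher numbers stand for a stronger effect at the one concentration tested and lower numbers for a weaker effect), where compound 3 gives 0.8%. Its nearest neighbour is compound 2 `COc1ccc(/C=C/C(=O)c2ccc(O)cc2)cc1Br`, which in this assay gives 24.8%, and the furthest is compound 1 `COc1cc(O)ccc1/C=C/C(=O)c1ccc(NC(C)=O)cc1`, which in this assay gives 100%. For the measured compounds named here, the only measured step that alters one place sits on the same position: a number 99.2 percentage points lower from compound 1 to compound 3 (beyond the scatter), a large drop beyond the scatter. Compound 4 `COc1cc(O)ccc1/C=C/C(=O)c1ccc(F)cc1` differs from compound 3 in that same place, but by another exchange: fluoro in place of amino on an aromatic carbon. Going by the values given here, no measured pair shows this exchange. Among the compounds with values here, the step from compound 1 to compound 3 shows only that a change at this place can move the read-out far; compound 2 carries a different set of groups, and no single step links it to compound 3. Within the data shown here, in the measured set, amino stands at the lowest value and the acetylated nitrogen at the highest, so a fluoro group has no direct precedent here. A modest rise is expected, a number 29.2 percentage points higher from compound 3 to compound 4 (beyond the scatter), with wide room on both sides. Compound 4 is therefore estimated at 30%, in a range from 0% to 75%.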

Compound 4, a percentage reported as inhibition, at one concentration (the size of the read-out at that concentration, not a potency): 95.8%
Estimate against measurement, compound 4: 65.8 percentage points below, outside the stated range (above it).
By their numbers in this assay, from the lowest: compound 3; then compound 2; then compounds 4 and 1 (each within the scatter of the next).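

In this assay this position on the six-membered aromatic ring is now seen to tolerate more than the acetylated nitrogen: a number 95 percentage points higher from compound 3 to compound 4 (beyond the scatter), a large rise on exchanging amino for fluoro. The other new step, a number 4.2 percentage points lower from compound 1 to compound 4 (within the scatter), shows that acetamido and fluoro cannot be told apart on this read-out, so a high number at this place does not depend on the acetamido group, and among the three groups compared here, amino alone gives a low number. Nothing available explains why the free amino compound stands so far from the other two, and the data offer no account of this change.

The compounds shown leave open how other groups would behave at this place, such as a chlorine, a methoxy group, a hydroxyl, a carboxylic acid or a dimethylamino group, and whether a second amine of this kind would also give a low number. Because each compound was read at a single concentration, they also leave open whether compound 1 and compound 4 would differ, with a stronger or weaker effect, at other concentrations.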